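The source may hold more compounds than are shown below. What is called first, only, known or untested is meant among the compounds shown, and "the series" means these compounds.

Measured compounds:
- compound 1 `Nc1scc(CN2CCN(c3ccc(OC(F)(F)F)cc3)CC2)c1C(=O)c1ccc(Cl)cc1`: 0%
- compound 2 `Nc1scc(CN2CCN(c3cccc(F)c3)CC2)c1C(=O)c1cccc(C(F)(F)F)c1`: -11%
- compound 3 `Nc1scc(CN2CCN(c3c(F)cccc3F)CC2)c1C(=O)c1cccc(C(F)(F)F)c1`: 2.1%

All three were run in a functional assay on CHO cells with adenosine receptor A1 (Homo sapiens) as the target, read by cAMP accumulation and immunoassay, with a stated time of 6 min, tested at 0.01 uM; on this read-out higher numbers stand for a weaker effect at the one concentration tested and lower numbers for a stronger effect. Compound 1 stands second highest of the three; compound 3 lies within the scatter of it, while compound 2 sits beyond the scatter below it. The unmeasured compound 4 `Nc1scc(CN2CCN(c3ccc(F)c(Cl)c3)CC2)c1C(=O)c1ccc(Cl)cc1` differs from compound 1 only at the aryl group on the ring nitrogen: 3-chloro-4-fluorophenyl in place of 4-(trifluoromethoxy)phenyl on an amine nitrogen in a ring. For the measured compounds named here, the one measured step at the same position, a number 13.1 percentage points higher from compound 2 to compound 3 (beyond the scatter), was modest, and the substituents there are not the same as here, so it guides only loosely. Little more than a shift inside or just beyond the scatter is expected, with no clear direction; the expected step is a number 1 percentage points higher from compound 1 to compound 4 (within the scatter). Compound 4 is estimated at 1%, range -12% to 14%.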

Compound 4, a percentage reported as activity, at one concentration (the size of the read-out at that concentration, not a potency): 4.2%
Estimate against measurement, compound 4: 3.2 percentage points below, within the range that was stated.
By their numbers in this assay, from the lowest: compound 2; then compounds 1, 3 and 4 (each within the scatter of the next).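

In this assay, 3-chloro-4-fluorophenyl in place of 4-(trifluoromethoxy)phenyl on an amine nitrogen in a ring gives a number 4.2 percentage points higher from compound 1 to compound 4 (within the scatter). Thus, on the core of compound 1, this position accepts a change to a group with fewer heavy atoms and the loss of the hydrogen-bond acceptor without a step beyond the scatter. No measurement at hand accounts for this step. As far as these compounds go, it remains open whether an aryl group carrying a carboxylic acid or an amine, or a benzyl group in place of the aryl group, would move the read-out beyond the scatter.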